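The source may hold more compounds than are shown below. What is called first, only, known or untested is meant among the compounds shown, and "the series" means these compounds.

Compound 1, `Cc1ccc(OCC(=O)N2CCN(c3ccc(C(F)(F)F)cc3[C@@H](N)CC(C)C)CC2)cc1`: 4400 nM
Compound 2, `CC(C)C[C@H](N)c1cc(C(F)(F)F)ccc1N1CCN(C(=O)CCC2CCCCC2)CC1`: 5700 nM
Compound 3, `COc1ccc(CC(C)C(=O)N2CCN(c3ccc(C(F)(F)F)cc3[C@@H](N)CC(C)C)CC2)cc1`: 120 nM

In an assay on HEK293 cells for displacement of a labelled ligand from Melanocortin receptor 4 (Homo sapiens) (on this read-out higher numbers stand for weaker inhibition and lower numbers for stronger inhibition), compound 3 gives 120 nM, the lowest of the three numbers by a wide margin. The two other compounds sit far above it: the change is a 37-fold lower number from compound 1 to compound 3 (1.56 log units; beyond the scatter) and a 48-fold lower number from compound 2 to compound 3 (1.68 log units; beyond the scatter). Both of those steps replaced the whole group on the carbonyl carbon, so they show that the branched benzyl-bearing group of compound 3 is a strong choice, but they say nothing about swapping substituents on its aromatic ring.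

Compound 4, `Cc1cc(Cl)ccc1CC(C)C(=O)N1CCN(c2ccc(C(F)(F)F)cc2[C@@H](N)CC(C)C)CC1`, keeps that branched group and changes only the ring at its end: 4-chloro-2-methylphenyl in place of 4-methoxyphenyl on a saturated chain carbon, two bonds along the chain from a carbonyl carbon. Going by the values given here, no measured step tests a swap of this kind. Among the compounds with values here, the only step that touched a distal ring without altering the chain, a 1.3-fold higher number from compound 1 to compound 2 (0.11 log units; within the scatter), exchanged an aromatic ring for a saturated one and stayed within the scatter. Within the data shown here, that is the closest precedent, and it suggests the distal ring identity moves the number little once the chain is fixed.

The expectation for compound 4 is therefore a number close to that of compound 3, with any step in either direction likely staying within the scatter: a 1.3-fold higher number from compound 3 to compound 4 (0.10 log units; within the scatter). The estimated value for compound 4 is 150 nM, with a range from 40 nM to 600 nM.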

Compound 4, inhibition constant: 38 nM
Estimate against measurement, compound 4: 3.9-fold (0.60 log units) above; measured number outside the range, below it.
By their numbers in this assay, from the lowest: compound 4; then compound 3; then compounds 1 and 2 (each within the scatter of the next).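

In this assay, the ring on a saturated chain carbon, two bonds along the chain from a carbonyl carbon, turns out to matter: 4-chloro-2-methylphenyl in place of 4-methoxyphenyl gives a 3.2-fold lower number from compound 3 to compound 4 (0.50 log units; beyond the scatter), a step beyond the scatter, whereas the earlier ring exchange, made together with a change in the link to that ring, gave only a 1.3-fold higher number from compound 1 to compound 2 (0.11 log units; within the scatter). The branched group therefore still has room for improvement through its ring, and the whole-group steps now reach a 120-fold lower number from compound 1 to compound 4 (2.06 log units; beyond the scatter) and a 150-fold lower number from compound 2 to compound 4 (2.18 log units; beyond the scatter), both wider than the steps from these compounds to compound 3. No measurement available here explains why this ring change strengthens inhibition.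

The step from compound 3 to compound 4 changes two things at once, since a methoxy group gives way to a chlorine and a methyl group also appears, so the compounds shown cannot say which of these matters. Going by these compounds, a 4-chlorophenyl group and a 4-methoxy-2-methylphenyl group on the same branched chain would separate the two, and the effect of an amine on this ring remains open as well.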